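The source may hold more compounds than are shown below. What is called first, only, known or untested is meant among the compounds shown, and "the series" means these compounds.

In a functional assay on PC-9 cells (Homo sapiens) for inhibition, read by MTT assay, with a stated time of 72 h (a lower number here means a stronger inhibitor, a higher number a weaker inhibitor), compound 1 `CCCCCc1c(C)nc2nc(SCc3ccc(Cl)cc3)nn2c1Nc1cc(-c2ccccc2)[nH]n1` gives > 50000 nM, which is a limit of the assay and not a number. For the measured compounds named here, compound 2 `Cc1cc(Nc2cc(-c3ccccc3)[nH]n2)n2nc(SCc3ccc(Cl)cc3)nc2n1` gives 6710 nM, the only actual number so far.

Compound 3 `Cc1nc2nc(SCc3ccc(Cl)cc3)nn2c(Nc2cc(-c3ccccc3)[nH]n2)c1C` departs from compound 2 by one change: methyl in place of hydrogen on an aromatic carbon. In words, this is methyl in place of hydrogen on an aromatic carbon.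

Going by the values given here, one measured step bears on this change. It is an at least 7.4-fold lower number from compound 1 to compound 2 (0.87 log units; beyond the scatter), with hydrogen in place of pentyl on that same aromatic carbon. As it starts from a limit, it fixes only a minimum size. It does show that a pentyl group at this place goes with a higher number in this assay than hydrogen does. Methyl is a much shorter group than pentyl, so only part of that step is expected to carry over, and in the same direction. The expected change is a 2.1-fold higher number from compound 2 to compound 3 (0.32 log units; beyond the scatter), a small move toward a higher number.

For compound 3, the estimated value is 14000 nM, with an expected range from 4500 nM to 45000 nM.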

Compound 3, half-maximal inhibitory concentration: > 50000 nM
Compound 3 was reported as a limit (the forecaster's own chance of this, stated with the estimate: 20%); at least 3.5-fold (0.55 log units) between middle value and limit.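

The earlier pair showed only that pentyl on this aromatic carbon goes with a higher number than hydrogen, and it left open whether a short group would do the same. In this assay, the step of an at least 7.4-fold higher number from compound 2 to compound 3 (0.87 log units; beyond the scatter) shows that methyl, with its 1 heavy atom, is already enough to take the compound out of the range the assay can read, a far larger move than a small share of the pentyl step. With methyl and pentyl both at the limit, the step between compound 1 and compound 3 cannot be read, so no trend with chain length can be drawn, and compound 3 gives a limit and not a number: the limit of > 50000 nM in this assay, at which 2 of the 3 values shown sit.

Hydrogen remains the only group at this place with an actual number, since compound 2 gives 6710 nM, and it is open whether a fluorine atom, a hydroxyl group or an amine here would keep a readable value. Going by these compounds, how far compound 1 and compound 3 actually lie from each other also stays open.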